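Methoxy gives way to tert-butyl in compound 4

The compounds below may be only part of what the source reports. "The series", "measured", "known", "first", "only" and "open" are said of these compounds alone.

Of the compounds shown here, three with a shared core have been tested in a physicochemical assay for solubility, in phosphate buffer, at pH 7.4; a higher number here means a more soluble compound, a lower number a less soluble compound. Compound 1 (`CCOC(=O)c1c(-c2ccccc2C)[nH]c2cc(OC)ccc2c1=O`) gives > 100000 nM, which is a limit and not a number. Compound 3 (`CCOC(=O)c1c(-c2ccccc2)[nH]c2cc(OC)ccc2c1=O`) gives > 100000 nM, again a limit. Compound 2 (`CCOC(=O)c1c(-c2ccc(OC)cc2)[nH]c2cccc(OC)c2c1=O`) gives > 100000 nM, also a limit, so its standing is known only as a bound and not as a number.

Compound 4 (`CCOC(=O)c1c(-c2ccc(C(C)(C)C)cc2)[nH]c2cccc(OC)c2c1=O`) differs from compound 2 in one place: tert-butyl in place of methoxy on an aromatic carbon, para to a large group (tert-butyl in place of methoxy on an aromatic carbon).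

Going by the values given here, the only measured step is a step that the two limits leave unreadable from compound 1 to compound 3, and it is a different change, hydrogen in place of methyl on an aromatic carbon. It therefore offers no size to carry over. What remains is the limit of > 100000 nM in this assay, at which 3 of the 3 values shown sit.

The expectation therefore rests on that limit alone: compound 4 should stay close to it and may well be reported only as a limit. A readable number would have to lie under the limit of compound 2, so the estimated change is small and downward, namely an at least 1.1-fold lower number from compound 2 to compound 4 (0.04 log units; that floor lies within the scatter). For compound 4 the estimate is 90000 nM, with an expected range of 20000 nM to 150000 nM.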

Compound 4, solubility: 1000 nM
Estimate against measurement, compound 4: 90-fold (1.95 log units) above; the measured number lies below the stated range.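

In this assay, placing tert-butyl instead of methoxy on this aromatic carbon, para to a large group, gives an at least 100-fold lower number from compound 2 to compound 4 (2.00 log units; beyond the scatter) and this is a large step, well beyond the scatter. It shows that this position is not indifferent to the group it carries: a single change, with the rest of the structure held the same, is enough to bring the read-out down to a measurable number. Without compound 4, the compounds shown would offer nothing but a limit, with no size for any change: the limit of > 100000 nM in this assay, at which 3 of the 4 values shown sit.

Going by these compounds, one pair cannot separate the departure of the methoxy oxygen from the arrival of the larger all-carbon group, so it remains open whether an amine, a carboxylic acid or a longer chain at this position would stay at the limit or fall as far as tert-butyl does. On these data alone, it is also open whether tert-butyl would bring a similar drop on the core of compound 3, where the methoxy group on the shared core sits elsewhere.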